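The source may hold more compounds than are shown below. What is called first, only, known or untested is meant among the compounds shown, and "the series" means these compounds.

Among the compounds with values here, compound 2 `N#CC1=C(N)N(c2ccc(S(N)(=O)=O)cc2)C2=C(CCCC2)C1c1c(O)ccc2ccccc12` stands highest of the two numbers measured so far in a functional assay on Ehrlich cells (Mus musculus) for cytotoxicity, read by trypan blue exclusion, with a stated time of 2 h, tested at 100 ug/mL; a lower number here means a weaker effect, a higher number a stronger effect of the compound at the concentration tested: compound 2 gives 50%. Within the data shown here, its only neighbour, compound 1 `N#CC1=C(N)N(c2ccc(S(N)(=O)=O)cc2)C2=C(CCCC2)C1c1cccc([N+](=O)[O-])c1`, gives 12% in this assay, and the step of a number 38 percentage points higher from compound 1 to compound 2 (beyond the scatter) shows that exchanging the group on this saturated ring carbon can shift the read-out strongly. Compound 3 `Cc1ccc(C2C(C#N)=C(N)N(c3ccc(S(N)(=O)=O)cc3)C3=C2CCCC3)o1` carries another such exchange: 5-methylfuran-2-yl in place of 2-hydroxynaphthalen-1-yl on a saturated ring carbon. That one step bears on it and was large; it is therefore expected that a number 25 percentage points lower from compound 2 to compound 3 (beyond the scatter) falls, since the group that gave the high number leaves. Compound 3 is estimated at 25%, within 8% to 50%.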

Compound 3, a percentage reported as activity, at one concentration (the size of the read-out at that concentration, not a potency): 30%
Beside the measured number, compound 3's estimate is 5 percentage points below it; the range from low to high includes it.
By their numbers in this assay, from the lowest: compound 1; then compound 3; then compound 2.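

At this saturated ring carbon, this assay records a number 20 percentage points lower from compound 2 to compound 3 (beyond the scatter) and also a number 18 percentage points higher from compound 1 to compound 3 (beyond the scatter) for the same 5-methylfuran-2-yl group. This group therefore lands between 2-hydroxynaphthalen-1-yl and 3-nitrophenyl, so the position gives an intermediate read-out as well as a high and a low one. No measurement at hand explains this order. As far as these compounds go, because the groups differ in several features at once, the part played by the hydroxyl of 2-hydroxynaphthalen-1-yl or by its two rings remains open. From the compounds shown here alone, what an amine or a carboxylic acid at this carbon would give also remains open.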